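Terminal hydroxy removed from the decyl chain of compound 1

The source may report more compounds than this note shows. Statements on the series, on what has been measured and on what is new or still open speak of the compounds shown alone.

Compound 1 `Cc1c(N(C)C)nc(CCCCCCCCCCO)c(O)c1C` is the stronger of the two compounds measured in a functional assay on cells (Lymphocyte, Homo sapiens), read by trypan blue exclusion, with a stated time of 16 h, tested at 0.5 uM; on this read-out higher numbers stand for a stronger effect at the one concentration tested and lower numbers for a weaker effect; compound 1 gives 36%. The other measured compound, compound 2 `CCCCCCCCCCCCCCCCCCCc1c(C)c(N(C)C)nc(C)c1O`, carries a long unsubstituted chain on its core, and in this assay compound 2 gives 8%, a number well below that of compound 1. Within the data shown here, no single-change step between measured compounds is available, so the effect of any one change on the read-out remains open.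

Compound 3 `CCCCCCCCCCc1nc(N(C)C)c(C)c(C)c1O` keeps the core and the chain of compound 1 and differs in one place: hydrogen in place of hydroxy on a saturated chain carbon, ten or more bonds along the chain from an aromatic carbon. Among the measured compounds shown here, since the only comparison at hand, compound 2 with its bare chain at 8%, sits far lower than compound 1, a modest loss in this assay is expected for this step. The step of a number 12 percentage points lower from compound 1 to compound 3 (beyond the scatter) is the estimate meant here. Compound 3 is therefore expected to give about 24%, within a range from 10% to 40%.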

Compound 3, a percentage reported as activity, at one concentration (the size of the read-out at that concentration, not a potency): 77%
Beside the measured number, compound 3's estimate is 53 percentage points below it; the measured number lies above the stated range.
By their numbers in this assay, from the lowest: compound 2; then compound 1; then compound 3.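

In this assay, the hydroxy on a saturated chain carbon is not required for the effect: hydrogen in its place brings a number 41 percentage points higher from compound 1 to compound 3 (beyond the scatter) and gives the series its first single-change comparison. With the rest of the structure unchanged, this place on the chain clearly bears on the read-out, and the free hydroxy there goes with the lower number of this pair. Nothing available accounts for the size of this step.

Going by these compounds, it remains open whether other groups at this place, such as methoxy, an amine or a carboxylic acid, would follow compound 3 or compound 1. The effect of a shorter or longer chain also remains open, as no pair shown differs in chain length alone.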